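The compounds below may be only part of what the source reports. "The series", "measured", "known", "first", "only" and "open" are said of these compounds alone.

Working notes on the series, read in a functional assay on HeLa cells (Homo sapiens) for antiproliferative activity, read by MTT assay, with a stated time of 72 h; a lower number here means a stronger inhibitor, a higher number a weaker inhibitor. Compound 1 `COc1ccc(N2CCN(C(=S)SCc3ccc4nc(N)nc(N)c4c3)CC2)cc1` gives 1660 nM and compound 2 `Cc1ccc(N2CCN(C(=S)SCc3ccc4nc(N)nc(N)c4c3)CC2)cc1` gives 2130 nM, and between these two stands a 1.3-fold higher number from compound 1 to compound 2 (0.11 log units; within the scatter). Compound 3 `Nc1nc(N)c2cc(CSC(=S)N3CCN(c4ccc(Cl)cc4)CC3)ccc2n1` gives 6990 nM, the weakest of the measured set. Its standing rests on two steps: a 4.2-fold higher number from compound 1 to compound 3 (0.62 log units; beyond the scatter), and a 3.3-fold higher number from compound 2 to compound 3 (0.52 log units; beyond the scatter).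

Compound 4 `Nc1nc(N)c2cc(CSC(=S)N3CCN(c4ccc(Cl)c(Cl)c4)CC3)ccc2n1` takes 4-chlorophenyl to 3,4-dichlorophenyl, with chloro in place of hydrogen, ortho to a chloro group and meta to a large group: chloro in place of hydrogen on an aromatic carbon. Going by the values given here, no measured pair shows this exact swap, so the evidence is indirect. The nearest guides are the same two steps into compound 3, a 4.2-fold higher number from compound 1 to compound 3 (0.62 log units; beyond the scatter) and a 3.3-fold higher number from compound 2 to compound 3 (0.52 log units; beyond the scatter), where a chloro enters on an aromatic carbon and the number rises modestly. Those steps replace methoxy and methyl, however, not hydrogen, so they support only a weak lean towards a higher number. No step beyond the scatter is expected in this assay. The estimated change is a 1.1-fold higher number from compound 3 to compound 4 (0.06 log units; within the scatter). For compound 4 the expected value is 8000 nM, with an estimated range of 3000 nM to 20000 nM.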

Compound 4, half-maximal inhibitory concentration: 3060 nM
Compound 4: the middle estimate sits 2.6-fold (0.42 log units) above what was measured, within the range that was stated.
By their numbers in this assay, from the lowest: compounds 1, 2 and 4 (each within the scatter of the next); then compound 3.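

On the 4-chlorophenyl group of compound 3, a chloro that enters ortho to a chloro group and meta to a large group gives a 2.3-fold lower number from compound 3 to compound 4 (0.36 log units; beyond the scatter) in this assay and is the only step shown in which a chloro replaces hydrogen, so this position accepts the extra atom and the number falls, whereas the steps into compound 3 went upward. Set against the other two aryl groups, the 3,4-dichlorophenyl group shows a 1.4-fold higher number from compound 2 to compound 4 (0.16 log units; within the scatter) and a 1.8-fold higher number from compound 1 to compound 4 (0.27 log units; within the scatter), so within these four compounds a second chloro brings the series back out of the gap that opened at compound 3. No measurement bears on why the second chloro moves the number this way.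

Open, as far as these compounds go, is whether this lower number belongs to chloro as such or would also follow from a methyl or a methoxy at the same place on a ring that keeps its first chloro. Also open, from the compounds shown here alone, is how a trifluoromethyl, a nitrile or an amine would read there, and whether any of these would give a number clearly lower than that of compound 1.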